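A few compounds are considered here, and "the series" means these few. Any claim that something is new, unique, unknown or untested is made for them only; others in the source may bear on it.

Measured compounds:
- compound 1 `Cc1c(C(=O)N/N=C\c2cccc(F)c2)oc2cccc(O)c12`; in a functional assay on PC-3 cells (Homo sapiens) for inhibition (a higher number here means a weaker inhibitor, a lower number a stronger inhibitor), compound 1 reports >= 40000 nM, which is a limit of the assay and not a number.
- compound 2 `Cc1ccc(O)c(/C=N\NC(=O)c2oc3cccc(O)c3c2C)c1`; compound 2 gives 7350 nM.
- compound 3 `Cc1c(C(=O)N/N=C\c2ccco2)oc2cccc(O)c12`; compound 3 reports >= 40000 nM, again a limit of the assay and not a number.

Compound 1 therefore stands only at a limit, with no measured number of its own, and it shares that position with compound 3 (the limit of >= 40000 nM in this assay, at which 2 of the 3 values shown sit). The one readable move in the set is an at least 5.4-fold lower number from compound 1 to compound 2 (0.73 log units; beyond the scatter); the reverse exchange an at least 5.4-fold higher number from compound 2 to compound 3 (0.73 log units; beyond the scatter) returns to the limit, while a step that the two limits leave unreadable from compound 1 to compound 3 cannot be sized because both of its ends are limits.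

Compound 4 `Cc1c(C(=O)N/N=C\c2ccc(O)cc2O)oc2cccc(O)c12` differs from compound 1 by 2,4-dihydroxyphenyl in place of 3-fluorophenyl on a carbon with a double bond to nitrogen. Like the 2-hydroxy-5-methylphenyl of compound 2, the entering 2,4-dihydroxyphenyl carries hydroxyl groups, so the step from compound 1 to compound 2 is the closest guide, whereas the furan-2-yl of compound 3 offers no parallel. On that basis the expected change is an at least 4.0-fold lower number from compound 1 to compound 4 (0.60 log units; beyond the scatter), a step downward beyond the scatter, though with a fair chance that this assay again reports only a limit. Compound 4 is accordingly estimated at 10000 nM, within a range of 3000 nM to 40000 nM.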

Compound 4, half-maximal inhibitory concentration: 14800 nM
The estimate for compound 4 lay 1.5-fold (0.17 log units) below the measured number; measured number inside the range.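

In this assay, a second phenyl group carrying hydroxyl on the carbon with a double bond to nitrogen gives a measured number, with an at least 2.7-fold lower number from compound 1 to compound 4 (0.43 log units; beyond the scatter) and with an at least 2.7-fold lower number from compound 3 to compound 4 (0.43 log units; beyond the scatter), so compound 2 no longer stands alone off the limit. Among the four compounds, only the two hydroxyl-bearing phenyl groups give numbers, and the exchange between them, a 2.0-fold higher number from compound 2 to compound 4 (0.30 log units; within the scatter), does not separate them. The two lower steps remain bounds only, because compound 1 and compound 3 each stand at a limit of the assay and not at a number: the limit of >= 40000 nM in this assay, at which 2 of the 4 values shown sit.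

The compounds shown do not tell whether the hydroxyl itself is what matters at this carbon, a question that a methoxy or an amine on the same phenyl ring would address. They also leave open how far the number can fall, and whether the shared core tolerates change, for example a carboxylic acid or a longer chain in place of its methyl.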